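Sulfonyl group exchange: from compound 2 to compound 3

The source may hold more compounds than are shown below. What is called first, only, known or untested is meant among the compounds shown, and "the series" means these compounds.

Among the measured compounds shown here, in a physicochemical assay for solubility, in simulated intestinal fluid, with a stated time of 4 h (a lower number here means a less soluble compound, a higher number a more soluble compound), compound 1 (`N#Cc1ccc(O[C@H]2CN(S(=O)(=O)c3ccc(Cl)cc3Cl)C[C@@]2(O)CO)cc1F`) gives 19 ug/mL and compound 2 (`N#Cc1ccc(O[C@H]2CN(S(=O)(=O)c3ccc(Cl)cn3)C[C@@]2(O)CO)cc1F`) gives 26 ug/mL in the only two measurements so far. Compound 2 lies within the scatter of compound 1, so the two cannot be ranked.

Compound 3 (`N#Cc1ccc(O[C@H]2CN(S(=O)(=O)c3ccc(Cl)cc3)C[C@@]2(O)CO)cc1F`) keeps the shared core and differs from compound 2 only on a sulfonyl sulfur: 4-chlorophenyl in place of 5-chloropyridin-2-yl on a sulfonyl sulfur, with 4-chlorophenyl in place of 5-chloropyridin-2-yl. For the measured compounds named here, one measured step bears on this change, as it falls at the same place. Given a 1.4-fold higher number from compound 1 to compound 2 (0.14 log units; within the scatter) with 5-chloropyridin-2-yl in place of 2,4-dichlorophenyl, a step within the scatter, no step beyond the scatter is expected in this assay for compound 3. A single step is thin support, so the range is kept wide. The expected change is a 1.2-fold lower number from compound 2 to compound 3 (0.07 log units; within the scatter) and it would not separate the two compounds. For compound 3 the estimate is 22 ug/mL, with an expected range from 10 ug/mL to 45 ug/mL in repeat measurements.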

Compound 3, solubility: 44 ug/mL
Compound 3: middle estimate off by 2.0-fold (0.30 log units), on the low side; low and high end bracket the measured number.
By their numbers in this assay, from the lowest: compounds 1, 2 and 3 (each within the scatter of the next, the first and the last beyond it).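

In this assay, 4-chlorophenyl in place of 5-chloropyridin-2-yl on the sulfonyl sulfur gives a step within the scatter (a 1.7-fold higher number from compound 2 to compound 3 (0.23 log units; within the scatter)), so this exchange does not rank compound 2 and compound 3. Among the compounds shown here, the new information comes from the other pair: hydrogen in place of chloro on an aromatic carbon gives the first step beyond the scatter (a 2.3-fold higher number from compound 1 to compound 3 (0.36 log units; beyond the scatter)), although it is modest and rests on a single pair of compounds. Nothing measured here accounts for either step.

From the compounds shown here alone, all three compounds carry a chlorinated six-membered aromatic ring on the sulfonyl sulfur, so it remains open how this read-out would respond to an amine or a carboxylic acid on that ring, or to a simple alkyl chain in place of the ring. The shared core is also unchanged throughout, which leaves open how the size of these steps would hold up with a different group elsewhere on the molecule.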